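The compounds below may be only part of what the source reports. "The series", "measured", "known", "first", "only" and "open" are said of these compounds alone.

Two compounds with the shared core have been run in a functional assay on the whole organism (strain Wistar) for inhibition, with Rattus norvegicus as the target, read by paw edema, with stated times of 60 min and 2 h, at a dose of 100 mg/kg by the oral route; on this read-out lower numbers stand for less inhibition and higher numbers for more inhibition at the one dose given (going by the name of the read-out). Compound 1 `COc1cc2c(cc1OC)C(CC(=O)O)CC2` carries a hydroxy on the carbonyl carbon, and in this assay compound 1 gives 24%. Compound 2 `COc1cc2c(cc1OC)C(CC(=O)NC(C)(C)C)CC2` carries (tert-butyl)amino in that place instead, and in this assay compound 2 gives 32%. The one measured step, a number 8 percentage points higher from compound 1 to compound 2 (within the scatter), is too small to separate the pair, so compound 2 sits at the top of the two numbers shown without standing apart from compound 1.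

Compound 3 `CCCCCNC(=O)CC1CCc2cc(OC)c(OC)cc21` has not yet been measured. It differs from compound 2 in one place: pentyl in place of tert-butyl on an amide-type nitrogen. Among the compounds with values here, no measured step touches a change of this kind; the only step at hand, a number 8 percentage points higher from compound 1 to compound 2 (within the scatter), concerns what sits on the carbonyl carbon rather than what the amide nitrogen carries, and it stayed within the scatter. On that thin basis the account expects no movement beyond the scatter, no change at the digits printed from compound 2 to compound 3 (within the scatter). For compound 3 the estimate in this assay is 32%, with a range from 18% to 46%.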

Compound 3, a percentage reported as inhibition, in the whole organism at one dose (the size of the read-out at that dose, not a potency): 34%
The estimate for compound 3 lay 2 percentage points below the measured number; measured number inside the range.
By their numbers in this assay, from the lowest: compounds 1, 2 and 3 (each within the scatter of the next).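

Within the data shown here, at the amide-type nitrogen, where no earlier step had reached, pentyl in place of tert-butyl comes to a number 2 percentage points higher from compound 2 to compound 3 (within the scatter) in this assay, so these two groups cannot be told apart in this read-out at the one dose given. Going back to the hydroxy on the carbonyl carbon, pentylamino in its place comes to a number 10 percentage points higher from compound 1 to compound 3 (within the scatter), which, together with the earlier step for (tert-butyl)amino, means that neither of the two amides shown stands apart from compound 1 at this position. No independent measurement bears on this result, and the data offer no explanation for it.

The compounds shown leave open whether any group on this nitrogen can move the number beyond the scatter, for instance a shorter chain such as methyl, a ring-bearing group such as benzyl or cyclohexyl, or a chain ending in an amine such as 2-(dimethylamino)ethyl. They also leave open how the unsubstituted amide, or an ester such as the ethyl ester in place of the hydroxy on the carbonyl carbon, would compare with compound 1 in this assay.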